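A few compounds are considered here, and "the series" means these few. Any claim that something is new, unique, unknown or untested is made for them only; others in the source may bear on it.

Compound 1 `COc1cc(C(=O)c2sc(Nc3ccc(F)cc3)nc2N)cc(OC)c1OC`: 400 nM
Compound 2 `COc1ccc(C(=O)c2sc(Nc3ccc(Cl)cc3)nc2N)cc1`: > 10000 nM (a limit, not a number)

In a functional assay on CCRF-CEM cells (Homo sapiens) for antiproliferative activity, read by cell counting, with a stated time of 2 days (on this read-out lower numbers stand for stronger inhibition and higher numbers for weaker inhibition), compound 1 gives a measured number, 400 nM. Compound 2 is reported only as a limit, > 10000 nM. It stands at the limit of > 10000 nM in this assay, at which 1 of the 2 values shown sits.

Compound 3 `COc1ccc(C(=O)c2sc(Nc3ccc(F)cc3)nc2N)cc1` differs from compound 2 in one place: fluoro in place of chloro on an aromatic carbon. This is fluoro in place of chloro on an aromatic carbon, para to a large group, or (4-chlorophenyl)amino to (4-fluorophenyl)amino.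

For the measured compounds named here, no measured step covers this exchange. The expectation in this assay is therefore a step of no size beyond the scatter, in neither direction, and another report as a limit is quite possible. The expected step of a number no higher from compound 2 to compound 3 (the limit leaves the size open) is only a rough estimate. For compound 3 the expected value is 10000 nM, with an estimated range of 3000 nM to 30000 nM.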

Compound 3, half-maximal inhibitory concentration: > 10000 nM
Compound 3 was reported as a limit; the forecaster's own chance of this, stated with the estimate: 70%; the middle value sits exactly at the limit.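

Compound 2 and compound 3 are both reported only as limits, and the step between them cannot be read: the limit of > 10000 nM in this assay, at which 2 of the 3 values shown sit.

The compounds shown leave open whether 4-fluorophenyl and 4-chlorophenyl differ at all in antiproliferative activity on this shared core.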